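This account rests on a few compounds, and the source may have more. Where it says the series, first, only, none or still open, it means among the compounds named here.

Three compounds built on one shared core were tested in a functional assay on PC-3 cells (Homo sapiens) for inhibition, read by MTT assay, with a stated time of 72 h; a higher number here means a weaker inhibitor, a lower number a stronger inhibitor. Compound 1, `Cc1ccc(-n2cc(CNC(=O)c3cccc4c3cnn4C(C)C)nn2)cc1C`, gives 23400 nM in this assay. Compound 3, `CC(C)n1ncc2c(C(=O)NCc3cn(-c4ccc(C(F)(F)F)cc4)nn3)cccc21`, gives 38600 nM in this assay. Compound 2, `CC(C)n1ncc2c(C(=O)NCc3cn(-c4ccc(F)cc4)nn3)cccc21`, gives > 40000 nM in this assay, and that value is a limit of the assay rather than a number (the limit of > 40000 nM in this assay, at which 1 of the 3 values shown sits). Of the two plain numbers, compound 3 holds the higher one, yet the step of a 1.6-fold higher number from compound 1 to compound 3 (0.22 log units; within the scatter) lies within the usual scatter. The step of an at least 1.7-fold higher number from compound 1 to compound 2 (0.23 log units; that floor lies within the scatter) and the step of an at least 1.0-fold lower number from compound 2 to compound 3 (0.01 log units; that floor lies within the scatter) likewise stay within the scatter. Swapping the group on the aromatic nitrogen among these three compounds therefore did not move the number in any reliable way.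

Compound 4, `CC(C)n1ncc2c(C(=O)NCc3cn(Cc4ccc(C#N)cc4)nn3)cccc21`, is the compound not yet measured. Relative to compound 3 the change is 4-cyanobenzyl in place of 4-(trifluoromethyl)phenyl on an aromatic nitrogen. For the measured compounds named here, no measured step replaces a phenyl with a benzyl or introduces a nitrile, so the only guide is that the three steps at this same position all remained inside the scatter. The expected step is thus small, with no clear direction, a 1.3-fold lower number from compound 3 to compound 4 (0.11 log units; within the scatter). For compound 4 the estimated value in this assay is 30000 nM, with a range from 10000 nM to 80000 nM.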

Compound 4, half-maximal inhibitory concentration: 18200 nM
Estimate against measurement, compound 4: 1.6-fold (0.22 log units) above; measured number inside the range.
By their numbers in this assay, from the lowest: compounds 4, 1 and 3 (each within the scatter of the next, the first and the last beyond it). At a limit, above all of these: compound 2.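

For the compounds shown here, at this position, on an aromatic nitrogen of the five-membered ring, compound 4 gives the first step in this assay that clears the scatter between two plain numbers: a 2.1-fold lower number from compound 3 to compound 4 (0.33 log units; beyond the scatter). The step of an at least 2.1-fold lower number from compound 2 to compound 4 (0.34 log units; beyond the scatter) also clears it, but it is only a floor, as compound 2 has a limit of the assay rather than a number: the limit of > 40000 nM in this assay, at which 1 of the 4 values shown sits. The group on this nitrogen can therefore shift the reading modestly, yet not against every neighbour, since a 1.3-fold lower number from compound 1 to compound 4 (0.11 log units; within the scatter) stays within the scatter, so compound 1 goes against any claim that 4-cyanobenzyl outperforms all the aryl groups shown.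

The change from compound 3 to compound 4 brings in the benzyl carbon and the nitrile together, and the compounds shown cannot divide the step between them. Going by these compounds, how a benzyl without the nitrile, a phenyl bearing a nitrile, or a ring carrying an amine or a carboxylic acid would read at this position stays open.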